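A few compounds are considered here, and "the series" means these few. Any claim that something is new, unique, unknown or untested is made for them only; others in the source may bear on it.

Measured compounds in a functional assay on MKN-45 cells (Homo sapiens) for cytotoxicity, read by MTT assay, with a stated time of 72 h; a lower number here means a stronger inhibitor, a higher number a weaker inhibitor:
compound 1 `COc1cc2c(Oc3ccc(NC(=O)c4cc(-c5cccc(Cl)c5)nc5ccccc45)cc3F)ccnc2cc1OCCCN1CCC(C)CC1` gives 30 nM
compound 2 `COc1cc2c(Oc3ccc(NC(=O)c4cc(-c5ccc(C)cc5)nc5ccc(F)cc45)cc3F)ccnc2cc1OCCCN1CCCCC1` gives 170 nM
compound 3 `COc1cc2c(Oc3ccc(NC(=O)c4cc(-c5cccc(Cl)c5)nc5ccc(F)cc45)cc3F)ccnc2cc1OCCCN1CCC(C)CC1` gives 10 nM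

Compound 3 carries the lowest of the three numbers in this assay; compound 1 sits nearest to it, compound 2 furthest. Among the measured compounds shown here, the one recorded single-point step, a 3.0-fold lower number from compound 1 to compound 3 (0.48 log units; beyond the scatter), concerns the fluoro and not the pendant aryl, so it does not speak to the change now considered.

Compound 4 `COc1cc2c(Oc3ccc(NC(=O)c4cc(-c5ccc(C)cc5)nc5ccc(F)cc45)cc3F)ccnc2cc1OCCCN1CCC(C)CC1` differs from compound 3 by 4-methylphenyl in place of 3-chlorophenyl on an aromatic carbon. For the measured compounds named here, no measured pair isolates this swap. Compound 2 also bears the 4-methylphenyl, yet it differs from compound 3 in a second place as well, so its number can only hint that the 4-methylphenyl costs potency. A weaker result than compound 3 is therefore expected, in line with compound 2 at 170 nM but tempered for the second difference. For compound 4 the estimate is 70 nM, range 25 nM to 220 nM, a step of a 7.0-fold higher number from compound 3 to compound 4 (0.85 log units; beyond the scatter) expected.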

Compound 4, half-maximal inhibitory concentration: 260 nM
For compound 4 the middle estimate is 3.7-fold (0.57 log units) below the measured one; measured number above the stated range.
By their numbers in this assay, from the lowest: compound 3; then compound 1; then compounds 2 and 4 (each within the scatter of the next).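

In this assay, the swap at this aromatic carbon next to the ring nitrogen is now isolated: 4-methylphenyl in place of 3-chlorophenyl gives a large loss (a 26-fold higher number from compound 3 to compound 4 (1.41 log units; beyond the scatter)), so this position is sensitive to the choice of aryl group. With 4-methylphenyl in place, the methyl on the saturated ring carbon makes no readable difference (a 1.5-fold higher number from compound 2 to compound 4 (0.18 log units; within the scatter)). Nothing measured here bears on the reason for the aryl step.

The compounds shown leave open whether the step follows the loss of chlorine, the gain of methyl or the shift in substituent position. A 4-chlorophenyl, a 3-methylphenyl and an unsubstituted phenyl at this carbon would separate these.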